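Shifting the methyl on the benzyl group of compound 2

The compounds below may be only part of what the source reports. "The series", "measured", "known", "first", "only" and "open" are said of these compounds alone.

In an assay on CHO cells for displacement of a labelled ligand from adenosine receptor A1 (Homo sapiens), read by scintillation counting, tested at 1 uM (a higher number here means more inhibition at the concentration tested (going by the name of the read-out), a lower number less inhibition), compound 2 `Cc1cccc(Cc2nc(N)c3nn(-c4ccccc4)cc3n2)c1` gives 41%, the lowest of the two numbers shown, while compound 1 `COc1ccc(Cc2nc(N)c3nn(-c4ccccc4)cc3n2)cc1` gives 48%. The step of a number 7 percentage points lower from compound 1 to compound 2 (within the scatter) is within the scatter. Compound 3 `Cc1ccc(Cc2nc(N)c3nn(-c4ccccc4)cc3n2)cc1` differs from compound 2 by 4-methylphenyl in place of 3-methylphenyl on a saturated chain carbon bound to an aromatic carbon. Among the measured compounds shown here, no measured step exchanges 3-methylphenyl for 4-methylphenyl; the only step available, from 4-methoxyphenyl to 3-methylphenyl, was small. For compound 3 one therefore expects a step of a number 2 percentage points higher from compound 2 to compound 3 (within the scatter) of no size beyond the scatter. The estimate for compound 3 is 43%, ranging from 30% to 56%.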

Compound 3, a percentage reported as inhibition, at one concentration (the size of the read-out at that concentration, not a potency): 38%
Compound 3: middle estimate off by 5 percentage points, on the high side, and the stated range covers the measured number.
By their numbers in this assay, from the lowest: compounds 3, 2 and 1 (each within the scatter of the next).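

In this assay, exchanging 3-methylbenzyl for 4-methylbenzyl gives a number 3 percentage points lower from compound 2 to compound 3 (within the scatter) and so does not tell the two placements of the methyl apart. Methyl in place of methoxy on an aromatic carbon, seen here as a single change for the first time, gives a number 10 percentage points lower from compound 1 to compound 3 (within the scatter) and also stays inside the scatter. Nothing at hand offers a reason for either step. On these data alone, whether an amine or a carboxylic acid in place of that methyl would move the number beyond the scatter remains open.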